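Replacing a methyl with a 3,4-dimethoxyphenyl group

This account rests on a few compounds, and the source may have more. Where it says the series, first, only, none or still open, it means among the compounds named here.

Measured compounds:
Compound 1 `CCN1C(=O)C(=O)c2cc(-c3ccc(OC)cc3)ccc21` gives 4470 nM
Compound 2 `COc1ccc(-c2ccc3c(c2)C(=O)C(=O)N3Cc2ccc(Cl)cc2)cc1` gives 250 nM
Compound 3 `COc1ccc(-c2ccc3c(c2)C(=O)C(=O)N3Cc2cc(C)cc(C)c2)cc1` gives 410 nM

These three compounds were tested in a functional assay on HepG2 cells (Homo sapiens) for antiproliferative activity, read by MTT assay, with a stated time of 48 h; on this read-out lower numbers stand for stronger inhibition and higher numbers for weaker inhibition. Within this set, compound 1 has the highest number, which here means the weakest inhibition; compound 3 stands nearest to it, and compound 2 furthest.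

The new compound, compound 4 `COc1ccc(-c2ccc3c(c2)C(=O)C(=O)N3Cc2ccc(OC)c(OC)c2)cc1`, differs from compound 1 in one place: 3,4-dimethoxyphenyl in place of methyl on a saturated chain carbon bound to an amide-type nitrogen in a ring. Within the data shown here, two measured steps bear directly on this change, since each also swaps the same methyl for an aromatic ring at the same place. The step of an 18-fold lower number from compound 1 to compound 2 (1.25 log units; beyond the scatter) and the step of an 11-fold lower number from compound 1 to compound 3 (1.04 log units; beyond the scatter) both gave large drops in the number, that is, clearly stronger inhibition. The two aromatic variants differ from each other only within the scatter, as the step of a 1.6-fold higher number from compound 2 to compound 3 (0.21 log units; within the scatter) shows, so the kind of ring appears to matter less than its presence among the compounds measured here.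

For compound 4 a similar large fall in the number is therefore expected, with the step of a 13-fold lower number from compound 1 to compound 4 (1.11 log units; beyond the scatter) estimated to resemble those seen for compound 2 and compound 3. The estimate for compound 4 in this assay is 350 nM, expected to fall between 150 nM and 900 nM.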

Compound 4, half-maximal inhibitory concentration: 1350 nM
Compound 4: the middle estimate sits 3.9-fold (0.59 log units) below what was measured; measured number outside the range, above it.
By their numbers in this assay, from the lowest: compounds 2 and 3 (each within the scatter of the next); then compound 4; then compound 1.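

In this assay an aromatic ring on this saturated chain carbon does not bring one uniform gain: 3,4-dimethoxyphenyl in place of methyl still gives a 3.3-fold lower number from compound 1 to compound 4 (0.52 log units; beyond the scatter) and so stronger inhibition, but the step is modest, whereas the two earlier rings gave large ones. The kind of ring therefore matters here, which the earlier pair could not show, as their rings stayed within the scatter of each other: moving to 3,4-dimethoxyphenyl gives a 3.3-fold higher number from compound 3 to compound 4 (0.52 log units; beyond the scatter) and also a 5.4-fold higher number from compound 2 to compound 4 (0.73 log units; beyond the scatter) and thus weaker inhibition, both steps lying beyond the scatter. Nothing available here accounts for this difference between the rings.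

Going by these compounds, whether a ring with a single methoxy group, such as 4-methoxyphenyl, would behave like 3,4-dimethoxyphenyl stays open, as does the outcome for a phenyl ring carrying an amine or a carboxylic acid. Every compound shown with a lower number than compound 1 carries an aromatic ring at this place, so it also stays open whether a longer saturated chain without a ring would lower the number too.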